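The source may report more compounds than this note shows. Statements on the series, on what has been measured and on what is new or still open speak of the compounds shown alone.

Measured so far in an ADME assay on TZM-b1 cells (Homo sapiens) for cytotoxicity, read by XTT assay, with a stated time of 3 days; a higher number here means that more compound is tolerated, a lower number that less compound is tolerated:
Compound 1, `Cc1nc(C(NC(=O)C(=O)Nc2ccc(C(F)(F)F)cc2)C2CCCCN2)sc1CO`, gives > 75500 nM, a limit of the assay rather than a number.
Compound 2, `Cc1nc(C(NC(=O)C(=O)Nc2ccc(Cl)cc2)C2CCCN2)sc1CO`, gives 12400 nM.
Compound 3, `Cc1nc(C(NC(=O)C(=O)Nc2ccc(Cl)cc2)C2CCCNC2)sc1CCO`, gives 59400 nM.

Compound 1 therefore stands at the top of what this assay reports: the limit of > 75500 nM in this assay, at which 1 of the 3 values shown sits. Its value sets only a floor, not a point.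

Compound 4, `Cc1nc(C(NC(=O)C(=O)Nc2ccc(F)cc2)C2CCCCN2)sc1CO`, differs from compound 1 in one place: fluoro in place of trifluoromethyl on an aromatic carbon. For the measured compounds named here, no measured pair carries this change, so no step size can be read from the data. Given the small size of the change, a step no larger than the scatter is expected in this assay, in either direction. Compound 4 is therefore expected to give about 60000 nM, within a range of 20000 nM to 150000 nM. That estimate means a step of an at least 1.2-fold lower number from compound 1 to compound 4 (0.09 log units; that floor lies within the scatter), most likely within the scatter.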

Compound 4, half-maximal cytotoxic concentration: > 90000 nM
Compound 4: no number, only a limit (the forecaster's own chance of this, stated with the estimate: 50%); middle value at least 1.5-fold (0.17 log units) from the limit.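

Compound 1 and compound 4 both give only limits of the assay, not numbers, so no step can be read between them. The compounds shown leave open whether 4-fluorophenyl and 4-(trifluoromethyl)phenyl differ at all in how much compound is tolerated.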